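Cytotoxicity Estimate for Compound 3

The source may report more compounds than this note shows. Statements on the series, on what has been measured and on what is new or still open speak of the compounds shown alone.

Measured compounds:
compound 1 `O=c1cc(-c2ccccc2)oc2cc(OCCCCNc3nc4ccc(Cl)cc4s3)cc(O)c12` — 338 ug/mL
compound 2 `O=c1cc(-c2ccccc2)oc2cc(OCCCCNc3nc4ccc(I)cc4s3)cc(O)c12` — 298 ug/mL

In an ADME assay on MDCK cells (Canis lupus familiaris) for cytotoxicity, read by sulforhodamine B assay, with a stated time of 48 h (a lower number here means a stronger inhibitor, a higher number a weaker inhibitor), compound 1 stands together with compound 2 inside the usual scatter, as the step of a 1.1-fold lower number from compound 1 to compound 2 (0.05 log units; within the scatter) shows. Compound 3 `O=c1cc(-c2ccccc2)oc2cc(OCCCCNNc3nc4ccccc4s3)cc(O)c12` differs from compound 1 by (1,3-benzothiazol-2-yl)amino in place of 6-chloro-1,3-benzothiazol-2-yl on an amine nitrogen. Among the measured compounds shown here, only the halogen swap has been measured, and it lay within the scatter; no measured step covers this change in the linking nitrogen. Compound 3 is therefore expected to move little, a 1.1-fold lower number from compound 1 to compound 3 (0.04 log units; within the scatter). The estimated value for compound 3 is 310 ug/mL, with a range from 150 ug/mL to 620 ug/mL.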

Compound 3, half-maximal inhibitory concentration: 316 ug/mL
Compound 3: the middle estimate sits 1.0-fold (0.01 log units) below what was measured, within the range that was stated.
By their numbers in this assay, from the lowest: compounds 2, 3 and 1 (each within the scatter of the next).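

In this assay, the change on the amine nitrogen gives a 1.1-fold lower number from compound 1 to compound 3 (0.03 log units; within the scatter) and a 1.1-fold higher number from compound 2 to compound 3 (0.03 log units; within the scatter). The earlier compounds shown here showed only a swap of one halogen for another; these steps show that a compound with no halogen and a (1,3-benzothiazol-2-yl)amino group also stays within the scatter of both halogen compounds. No available evidence accounts for this result. Still open, on these data alone, is whether a carboxylic acid or a morpholine in place of this group, or a longer chain, would give a step beyond the scatter.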